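A few compounds are considered here, and "the series" means these few. Any claim that something is new, unique, unknown or untested is made for them only; others in the source may bear on it.

Measured compounds in a functional assay on HeLa cells (Homo sapiens) for cytotoxicity, read by MTT assay, with a stated time of 48 h; on this read-out lower numbers stand for stronger inhibition and higher numbers for weaker inhibition:
Compound 1, `O=C(Nc1nc2ccc(F)cc2s1)c1cc(-c2ccc(F)cc2)n2nc(-c3ccccc3)cc2n1`: compound 1 gives 29500 nM
Compound 2, `COc1ccc2nc(NC(=O)c3cc(-c4ccc(F)cc4)n4nc(-c5ccccc5)cc4n3)sc2c1`: compound 2 gives 17300 nM
Compound 3, `Cc1cc2nc(NC(=O)c3cc(-c4ccc(F)cc4)n4nc(-c5ccccc5)cc4n3)sc2cc1C`: compound 3 gives 18200 nM

The three measured compounds lie close together. From compound 1 to compound 2 the change is methoxy in place of fluoro on an aromatic carbon, and it gives a 1.7-fold lower number from compound 1 to compound 2 (0.23 log units; within the scatter). The cores of compound 3 and compound 1 differ by 5,6-dimethyl-1,3-benzothiazol-2-yl in place of 6-fluoro-1,3-benzothiazol-2-yl on an amide-type nitrogen, and the step is a 1.6-fold lower number from compound 1 to compound 3 (0.21 log units; within the scatter); compound 2 and compound 3 differ by a 1.1-fold higher number from compound 2 to compound 3 (0.02 log units; within the scatter).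

Compound 4, `COc1ccc(-c2cc(C(=O)Nc3nc4cc(C)c(C)cc4s3)nc3cc(-c4ccccc4)nn23)cc1`, is not yet measured. It differs from compound 3 by methoxy in place of fluoro on an aromatic carbon. This is the same kind of change as from compound 1 to compound 2, but the place differs: there it sat on a ring that is part of a fused or bridged system of two rings, meta to a fused ring and para to a fused ring, whereas here it sits para to a large group. Because the earlier step was a 1.7-fold lower number from compound 1 to compound 2 (0.23 log units; within the scatter), only a small step is expected from compound 3 to compound 4 in this assay, estimated as a 1.3-fold lower number from compound 3 to compound 4 (0.11 log units; within the scatter). Compound 4 is thus expected to give about 14000 nM, within 6000 nM to 35000 nM.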

Compound 4, half-maximal inhibitory concentration: 14100 nM
Estimate against measurement, compound 4: 1.0-fold (0.00 log units) below; the measured number falls inside the stated range.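

In this assay the change from 4-fluorophenyl to 4-methoxyphenyl gives a 1.3-fold lower number from compound 3 to compound 4 (0.11 log units; within the scatter). Set beside the same replacement of fluoro by methoxy at a different place on another core, the two steps do not differ: the same change on two cores in this assay, a 1.7-fold lower number (0.23 log units; within the scatter) from compound 1 to compound 2 and a 1.3-fold lower number (0.11 log units; within the scatter) from compound 3 to compound 4, 1.3-fold (0.12 log units) apart, within the scatter of two such steps. For the compounds shown here, this shows only that the change stays within the scatter in both cases; with both steps that small, it does not show a real effect that carries from one core to another.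

From the compounds shown here alone, whether an amine or a carboxylic acid on the same aromatic carbon would move the number beyond the scatter remains open. The compounds shown also leave open whether a longer chain in place of the methoxy would do so.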